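Swapping the aryl group on the hydrazone carbon

A few compounds are considered here, and "the series" means these few. Any claim that something is new, unique, unknown or untested is made for them only; others in the source may bear on it.

Two compounds share one core: compound 1 `O=C(CSc1nnc(-c2ccncc2)o1)N/N=C/c1ccc(Br)cc1` and compound 2 `O=C(CSc1nnc(-c2ccncc2)o1)N/N=C/c1cc(Cl)ccc1O`. Among the compounds with values here, in a functional assay on SW 1116 cells (Homo sapiens) for cytotoxicity, read by MTT assay, with a stated time of 48 h (on this read-out lower numbers stand for stronger inhibition and higher numbers for weaker inhibition), compound 1 gives 21300 nM, whereas compound 2 gives 5240 nM, the lowest of the two numbers measured so far. Within the data shown here, the single step linking them, a 4.1-fold lower number from compound 1 to compound 2 (0.61 log units; beyond the scatter), is the only measured step available. Compound 3 `COc1cc(/C=N/NC(=O)CSc2nnc(-c3ccncc3)o2)ccc1O` has not yet been measured. It differs from compound 2 in one place: 4-hydroxy-3-methoxyphenyl in place of 5-chloro-2-hydroxyphenyl on a carbon with a double bond to nitrogen. Among the measured compounds shown here, no measured step exchanges one phenyl bearing a hydroxy group for another; the step from compound 1 to compound 2 shows only that changing the aromatic substituents on this carbon can move the number by a modest amount in either direction, and it gives no guide for this particular swap. On that basis, compound 3 is expected to sit near compound 2, with an estimated step of a 1.5-fold higher number from compound 2 to compound 3 (0.18 log units; within the scatter) that lies within the scatter. The estimate for compound 3 in this assay is 8000 nM, with a range from 2500 nM to 25000 nM.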

Compound 3, half-maximal inhibitory concentration: 3590 nM
Beside the measured number, compound 3's estimate is 2.2-fold (0.35 log units) above it, and the stated range covers the measured number.
By their numbers in this assay, from the lowest: compounds 3 and 2 (each within the scatter of the next); then compound 1.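

In this assay the exchange of one hydroxy-bearing phenyl for another on this carbon gives a 1.5-fold lower number from compound 2 to compound 3 (0.16 log units; within the scatter) and so does not separate 4-hydroxy-3-methoxyphenyl from 5-chloro-2-hydroxyphenyl, even though the two groups carry different substituents. Set against 4-bromophenyl, the new group gives a 5.9-fold lower number from compound 1 to compound 3 (0.77 log units; beyond the scatter) and thus joins 5-chloro-2-hydroxyphenyl on the same side of compound 1, so that among these three compounds both phenyl groups with a hydroxy group give lower numbers than the 4-bromophenyl group, and none of the three goes against this. Nothing available bears on the reason for this pattern.

The compounds shown leave open whether the hydroxy group or its companion substituent accounts for the difference from compound 1, as each hydroxy-bearing phenyl here also holds a chlorine or a methoxy group. Also open, as far as these compounds go, is how a phenyl bearing an amine or a carboxylic acid on this carbon would read in this assay.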